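Anilino to (4-methoxyphenyl)amino: expected shift for compound 3

The compounds below may be only part of what the source reports. "The series", "measured", "known", "first", "only" and "open" are said of these compounds alone.

Measured compounds
compound 1 `NC(=O)c1c(NC(=O)c2ccc(C(F)(F)F)cc2)sc2c1CCN(Cc1ccc(Cl)cc1)C2`: > 50000 nM
compound 2 `NC(=O)c1c(NC(=O)c2ccccc2Cl)sc2c1CCN(C(=S)Nc1ccccc1)C2`: 5940 nM

Two compounds have been run in a functional assay on HL-60 cells (Homo sapiens) for antiproliferative activity, with a stated time of 24 h; a lower number here means a stronger inhibitor, a higher number a weaker inhibitor. For compound 1 the reported > 50000 nM is a limit of the assay rather than a number, as stated in the limit of > 50000 nM in this assay, at which 1 of the 2 values shown sits. Going by the values given here, compound 2 gives 5940 nM in this assay, and this is the only actual number in the set. Among the compounds with values here, compound 1 and compound 2 differ in more than one place, so no single-change step between measured compounds is available, and compound 2 can only be placed as the one compound with a measured number.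

Compound 3 `COc1ccc(NC(=S)N2CCc3c(sc(NC(=O)c4ccccc4Cl)c3C(N)=O)C2)cc1` is not yet measured. It differs from compound 2 as follows: methoxy in place of hydrogen on an aromatic carbon. The measured pair gives no evidence on a methoxy at this place, and the limit of compound 1 bears on a different set of changes.

The step of a 1.2-fold lower number from compound 2 to compound 3 (0.07 log units; within the scatter) is expected to be small, with no direction beyond the usual scatter. Compound 3 is therefore expected to give about 5000 nM in this assay, within a range from 1500 nM to 15000 nM.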

Compound 3, half-maximal inhibitory concentration: 15700 nM
Compound 3: middle estimate off by 3.1-fold (0.50 log units), on the low side; the whole stated range lies below it.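

The series now has one single-change step in this assay: methoxy in place of hydrogen on an aromatic carbon, para to a large group, gives a 2.6-fold higher number from compound 2 to compound 3 (0.42 log units; beyond the scatter). This shows that the position on the anilino ring is not indifferent to substitution in this assay, as the change from anilino to (4-methoxyphenyl)amino moves the number towards weaker inhibition, a direction that the earlier pair could not show. No measured property bears on the reason for this step.

As far as these compounds go, one substituent at one place gives a single reading and not a trend, so it remains open whether the direction belongs to methoxy itself or would also appear with other groups at this place, such as an amine, a carboxylic acid, a hydroxy group or a longer alkoxy chain. Also open, from the compounds shown here alone, is whether the same change gives a step of similar size when the 2-chlorobenzoyl amide of the shared core is replaced, or when the methoxy stands at another carbon of the same aromatic ring.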